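From a fluorophenyl amide to a hydroxybenzyl amide

This account rests on a few compounds, and the source may have more. Where it says the series, first, only, none or still open, it means among the compounds named here.

The series shares one core, shown in compound 1 `CCOC(=O)c1cn(-c2nccs2)nc1CC(C)C`, where an ethoxy group sits on the carbonyl carbon. In a toxicity assay on HepG2 2.2.15 cells (Homo sapiens) for cytotoxicity, read by CCK-8 assay, with a stated time of 8 days (a lower number here means that less compound is tolerated, a higher number that more compound is tolerated), compound 1 reports only the limit of the assay, > 100000 nM. Compound 2 `CC(C)Cc1nn(-c2cccc(F)c2)cc1C(=O)NCc1ccc(F)cc1` likewise gives only the limit, > 100000 nM, in this assay. Among the measured compounds shown here, compound 3 `CC(C)Cc1nn(-c2nccs2)cc1C(=O)Nc1ccc(F)cc1` is the one member with a number in this assay, 83700 nM. For the measured compounds named here, the step of an at least 1.1-fold lower number from compound 1 to compound 3 (0.07 log units; that floor lies within the scatter) is the single measured step, and it stays within the scatter; the evidence around it is the limit of > 100000 nM in this assay, at which 2 of the 3 values shown sit.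

Compound 4 `CC(C)Cc1nn(-c2nccs2)cc1C(=O)NCc1ccc(O)cc1` is not yet measured. It differs from compound 3 as 4-hydroxybenzyl in place of 4-fluorophenyl on an amide-type nitrogen. Going by the values given here, no measured step changes the substituent on the amide-type nitrogen, so the one step from compound 1 to compound 3, itself within the scatter, is the only guide, and it bears on a different position. With every value shown at or near the limit, the author expects the step of a 1.1-fold higher number from compound 3 to compound 4 (0.03 log units; within the scatter) to lie within the scatter, with a fair chance that only a limit is reported. Compound 4 is therefore estimated at 90000 nM, between 40000 nM and 200000 nM, in this assay.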

Compound 4, half-maximal cytotoxic concentration: > 100000 nM
Compound 4 gave a limit, no number; the forecaster's own chance of this, stated with the estimate: 50%; middle value at least 1.1-fold (0.04 log units) away from the limit.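

The change on the amide-type nitrogen now has a measured step of its own: in this assay, 4-hydroxybenzyl in place of 4-fluorophenyl gives an at least 1.1-fold higher number from compound 3 to compound 4 (0.07 log units; that floor lies within the scatter). The value of compound 4 is a limit and not a number, so only the floor of this step can be read, and that floor does not separate the two compounds. The swap brings a hydrogen-bond donor and a hydrogen-bond acceptor onto this position, yet compound 4 adds no second number to the series, and compound 3 remains the only member with one, while the rest share a single reading: the limit of > 100000 nM in this assay, at which 3 of the 4 values shown sit.

From the compounds shown here alone, the change replaces the fluorine with a hydroxy group and adds a carbon to the substituent in one move, so the share of each in the step remains open, and a plain benzyl group on the same nitrogen would be needed to separate them. Also open, going by these compounds, is what this assay would report for an amine or a carboxylic acid in place of the hydroxy group, or for a longer chain in place of the benzyl carbon.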